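Lengthening the Chain on a Selenium-Containing Antiproliferative Core

The compounds below may be only part of what the source reports. "The series", "measured", "known", "first", "only" and "open" are said of these compounds alone.

Measured so far in a functional assay on HeLa cells (Homo sapiens) for antiproliferative activity, read by CCK-8 assay, with a stated time of 48 h; a lower number here means a stronger inhibitor, a higher number a weaker inhibitor:
compound 1 `CCCCCCSc1n[nH]c(-n2[se]c3ccccc3c2=O)n1` gives 35900 nM
compound 2 `O=c1c2ccccc2[se]n1-c1nc(SCc2ccccc2)n[nH]1` gives a limit, > 50000 nM
compound 3 `CCCSc1n[nH]c(-n2[se]c3ccccc3c2=O)n1` gives 30400 nM

In this assay compound 3 gives 30400 nM, a number that sits within the scatter of compound 1 at 35900 nM. Compound 2 gives only a limit of the assay, > 50000 nM, which is the limit of > 50000 nM in this assay, at which 1 of the 3 values shown sits.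

Compound 4 `CCCCSc1n[nH]c(-n2[se]c3ccccc3c2=O)n1` differs from compound 3 by methyl in place of hydrogen on a saturated chain carbon, three bonds along the chain from a sulfur. Among the measured compounds shown here, the one measured step at the same place, a 1.2-fold lower number from compound 1 to compound 3 (0.07 log units; within the scatter), stayed within the scatter, so no movement beyond the scatter is expected here either. The step from compound 3 to compound 4 is estimated as a 1.1-fold higher number from compound 3 to compound 4 (0.02 log units; within the scatter). Compound 4 is therefore expected to give 32000 nM, with a range from 18000 nM to 55000 nM.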

Compound 4, half-maximal inhibitory concentration: 32900 nM
Estimate against measurement, compound 4: 1.0-fold (0.01 log units) below, within the range that was stated.
By their numbers in this assay, from the lowest: compounds 3, 4 and 1 (each within the scatter of the next). At a limit, above all of these: compound 2.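

Adding a methyl at this place changes little in this assay: a 1.1-fold higher number from compound 3 to compound 4 (0.03 log units; within the scatter), and shortening the chain gives a 1.1-fold lower number from compound 1 to compound 4 (0.04 log units; within the scatter), so a third chain length now sits within the scatter of the other two. The comparison with the phenyl-bearing compound gives only a floor: an at least 1.5-fold lower number from compound 2 to compound 4 (0.18 log units; that floor lies within the scatter). Compound 2 remains a limit of the assay: the limit of > 50000 nM in this assay, at which 1 of the 4 values shown sits.

As far as these compounds go, whether any chain length at this place can move the number beyond the scatter remains open. An amine or a carboxylic acid at the chain end, or a much longer chain, could test this.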